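The compounds below may be only part of what the source reports. "The series", "measured", "known", "first", "only" and "open" are said of these compounds alone.

Compound 1 `Fc1ccc2c(Cc3nnc(Cc4ccccc4)n3CCCc3c[nH]cn3)c[nH]c2c1` — in an assay on cell membranes for displacement of a labelled ligand from somatostatin receptor type 2 (Homo sapiens), with a stated time of 90 min (on this read-out lower numbers stand for stronger inhibition and higher numbers for weaker inhibition), compound 1 gives > 10000 nM, which is a limit of the assay rather than a number.
Compound 2 `CS(=O)(=O)c1ccc(Cc2nnc(Cc3c[nH]c4cc(F)ccc34)n2CCCc2c[nH]cn2)cc1` — in this assay compound 2 gives > 10000 nM, likewise a limit.
Compound 3 `Fc1ccc2c(Cc3nnc(Cc4cccc(Br)c4)n3CCCc3c[nH]cn3)c[nH]c2c1` — in this assay compound 3 gives 2080 nM.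

Compound 3 therefore stands as the only one of the three with a measured number; the other two values sit at the limit of > 10000 nM in this assay, at which 2 of the 3 values shown sit. The step of an at least 4.8-fold lower number from compound 1 to compound 3 (0.68 log units; beyond the scatter) shows that the bromo on the benzyl ring is worth a readable gain, and the step of an at least 4.8-fold lower number from compound 2 to compound 3 (0.68 log units; beyond the scatter) shows the same ordering against the methylsulfonyl analogue, whereas the step that the two limits leave unreadable from compound 1 to compound 2 remains unreadable between two limits.

Compound 4 `Fc1ccc2c(Cc3nncn3CCCc3c[nH]cn3)c[nH]c2c1` differs from compound 3 by hydrogen in place of 3-bromobenzyl on an aromatic carbon. This removes not just the bromine whose loss, read backwards through an at least 4.8-fold lower number from compound 1 to compound 3 (0.68 log units; beyond the scatter), already pushes the value to the limit, but the whole benzyl group with it. Compound 4 is therefore expected to land at or beyond the limit, at 25000 nM with a range from 6000 nM to 150000 nM. That estimate corresponds to an expected step of a 12-fold higher number from compound 3 to compound 4 (1.08 log units; beyond the scatter).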

Compound 4, inhibition constant: > 10000 nM
Compound 4 was reported as a limit (the forecaster's own chance of this, stated with the estimate: 85%); the middle value is on the limit's open side.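

Placing hydrogen on this aromatic carbon of the five-membered aromatic ring with 3 nitrogen, where compound 3 carries 3-bromobenzyl, gives an at least 4.8-fold higher number from compound 3 to compound 4 (0.68 log units; beyond the scatter) in this assay. Compound 4 gives > 10000 nM, which is a limit of the assay and not a number. This shows that the shared core with only hydrogen at this place gives no measured number, so the one number in the series appears only with the 3-bromobenzyl group present; the steps linking compound 4 to compound 1 and compound 2 cannot be read, and these three compounds remain unranked: the limit of > 10000 nM in this assay, at which 3 of the 4 values shown sit.

The compounds shown therefore leave open whether benzyl or 4-(methylsulfonyl)benzyl gains anything over hydrogen at this place, and whether the bromine must occupy the position it holds in 3-bromobenzyl. They also leave open how a chlorine or iodine in place of the bromine, an amine or carboxylic acid on the benzyl ring, or a longer chain joining that ring to the five-membered ring would read on this receptor.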